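Adding methoxycarbonyl to compound 3

The source may hold more compounds than are shown below. What is called first, only, known or untested is meant among the compounds shown, and "the series" means these compounds.

In a functional assay on HT-29 cells (Homo sapiens) (on this read-out higher numbers stand for weaker inhibition and lower numbers for stronger inhibition), compound 1 (`Cc1ccc2nc(N)nc(O)c2c1Sc1ccc(C(=O)N[C@H](C(=O)O)c2ccccc2)cc1`) gives > 20000 nM as a limit of the assay and not a number. Compound 2 (`Cc1ccc2nc(N)nc(O)c2c1Sc1ccc(C(=O)N[C@H](C(=O)O)c2cccc(C(=O)O)c2)cc1`) gives 1200 nM and compound 3 (`COC(=O)[C@@H](NC(=O)c1ccc(Sc2c(C)ccc3nc(N)nc(O)c23)cc1)c1ccccc1`) gives 600 nM so these two lie within the scatter of each other and neither can be put ahead.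

Compound 4 (`COC(=O)c1cccc([C@H](NC(=O)c2ccc(Sc3c(C)ccc4nc(N)nc(O)c34)cc2)C(=O)OC)c1`) differs from compound 3 by a single change (methoxycarbonyl in place of hydrogen on an aromatic carbon) with methoxycarbonyl in place of hydrogen on an aromatic carbon. Among the compounds with values here, two measured steps bear on it. One is an at least 16-fold lower number from compound 1 to compound 2 (1.22 log units; beyond the scatter) with carboxy in place of hydrogen on an aromatic carbon, and the other is an at least 33-fold lower number from compound 1 to compound 3 (1.52 log units; beyond the scatter) with methyl in place of hydrogen on an oxygen next to a carbonyl group. Both are large, but both start from a limit. Compound 3 already carries the second change at 600 nM so only a small move toward a lower number is expected, not one beyond the scatter. The estimated move is a 1.3-fold lower number from compound 3 to compound 4 (0.12 log units; within the scatter) in this assay on this reasoning. For compound 4 the estimated value is 450 nM with 120 nM to 1800 nM as the expected range.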

Compound 4, half-maximal inhibitory concentration: 600 nM
Compound 4: the middle estimate sits 1.3-fold (0.12 log units) below what was measured, and the stated range covers the measured number.
By their numbers in this assay, from the lowest: compounds 3, 4 and 2 (each within the scatter of the next). At a limit, above all of these: compound 1.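

With the methyl ester in place, methoxycarbonyl on an aromatic carbon meta to a large group gives no change at the digits printed from compound 3 to compound 4 (within the scatter) in this assay, so this position takes the added group with no move beyond the scatter. Within the data shown here, the only earlier change at this position, carboxy, gave an at least 16-fold lower number from compound 1 to compound 2 (1.22 log units; beyond the scatter) on the free-acid background, so a large step there does not carry over to methoxycarbonyl on the ester background. The size of that earlier step remains unmeasured, as compound 1 stands at a limit and not a number: the limit of > 20000 nM in this assay, at which 1 of the 4 values shown sits.

Going by these compounds, whether a carboxylic acid at this position, with the methyl ester kept, would read as compound 4 does remains open. So does the outcome with an amine or an ethyl ester there.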